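A few compounds are considered here, and "the series" means these few. Any claim that something is new, unique, unknown or untested is made for them only; others in the source may bear on it.

Measured in a functional assay on DU-145 cells (Homo sapiens) for inhibition, read by MTT assay, with a stated time of 48 h; a lower number here means a stronger inhibitor, a higher number a weaker inhibitor:
- Compound 1 `Cc1ccc(-c2nc3ccccn3c2Sc2ccccc2)cc1`: 83300 nM
- Compound 2 `Cc1ccc2nc(-c3ccc(Cl)cc3)c(Sc3ccccc3)n2c1`: 95100 nM

Within the data shown here, compound 2 stands level with compound 1, the only other measured compound, as their two values lie within the scatter of each other. Compound 3 `Clc1ccc(-c2nc3ccccn3c2Sc2ccccc2)cc1` differs from compound 2 by hydrogen in place of methyl on an aromatic carbon, with hydrogen in place of methyl on an aromatic carbon. Among the measured compounds shown here, no measured step covers this change, so nothing beyond the scatter is expected in this assay. The expected step is a 1.2-fold lower number from compound 2 to compound 3 (0.08 log units; within the scatter). Compound 3 is expected at 80000 nM, with an estimated range of 35000 nM to 150000 nM.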

Compound 3, half-maximal inhibitory concentration: 30700 nM
Estimate against measurement, compound 3: 2.6-fold (0.42 log units) above; measured number outside the range, below it.
By their numbers in this assay, from the lowest: compound 3; then compounds 1 and 2 (each within the scatter of the next).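

In this assay the methyl on the six-membered aromatic ring with 1 nitrogen is not neutral: hydrogen in its place gives a 3.1-fold lower number from compound 2 to compound 3 (0.49 log units; beyond the scatter) and shows that this position can move the number beyond the scatter. Chloro in place of methyl on an aromatic carbon gives a 2.7-fold lower number from compound 1 to compound 3 (0.43 log units; beyond the scatter) so a single change from either earlier compound reaches a lower number, although compounds 1 and 2 stood level. No measurement on hand accounts for either step.

From the compounds shown here alone, whether an amine or a methoxy at the methyl position would lower the number further stays open. So does whether a fluoro in place of the chloro would keep the gain.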